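A few compounds are considered here, and "the series" means these few. Any claim that something is new, unique, unknown or untested is made for them only; others in the source may bear on it.

Measured compounds:
compound 1, `CCOC(=O)[C@]1(C(=O)Nc2ccccc2Cl)C[C@@H]1c1cc(OC)c(OC)c(OC)c1`, 50900 nM
compound 2, `CCOC(=O)C1(C(=O)Nc2ccccc2Cl)CC1c1cc(OC)c(OC)c(OC)c1`, 18000 nM; 18500 nM (2 entries)

Going by the values given here, in a functional assay on A549 cells (Homo sapiens) for cytotoxicity, read by MTT assay, with a stated time of 48 h (a higher number here means a weaker inhibitor, a lower number a stronger inhibitor), compound 1 gives 50900 nM; this is the only number it has in this assay, and one further entry for it carries no single number. Compound 2, drawn as `CCOC(=O)C1(C(=O)Nc2ccccc2Cl)CC1c1cc(OC)c(OC)c(OC)c1`, gives 18000 nM; 18500 nM (2 entries) in this assay, its record being (the several entries of compound 2 in this assay, 18000 nM; 18500 nM (2 entries)). Among the compounds with values here, no step is computed between compound 1 and compound 2, the two being separated by the fact that one of compounds 1 and 2 is drawn with a defined configuration and the other without, at the place where they differ, so their two values are simply noted side by side and nothing more is read from them.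

The step followed here runs from compound 1 to compound 3, `CCOC(=O)[C@]1(C(=O)NCc2ccc(C)cc2)C[C@@H]1c1cc(OC)c(OC)c(OC)c1`, which has not been measured. The change is 4-methylbenzyl in place of 2-chlorophenyl on an amide-type nitrogen.

Within the data shown here, no measured pair carries a change of this kind, so the expectation for this assay rests on no comparison. A step of a 1.1-fold lower number from compound 1 to compound 3 (0.05 log units; within the scatter) is expected, not beyond the usual scatter and with no preferred direction. Compound 3 is estimated at 45000 nM in this assay, with a wide range from 12000 nM to 200000 nM.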

Compound 3, half-maximal inhibitory concentration: 34900 nM
Beside the measured number, compound 3's estimate is 1.3-fold (0.11 log units) above it, within the range that was stated.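

In this assay the amide-type nitrogen now has its first readable change of substituent, with 4-methylbenzyl in place of 2-chlorophenyl giving a 1.5-fold lower number from compound 1 to compound 3 (0.16 log units; within the scatter) on the core of compound 1. Going by these compounds alone, this single pair shows that an aryl group placed directly on the nitrogen can be exchanged for a benzyl group, with the chlorine gone and a methyl added, without a step beyond the scatter, which the earlier compounds could not show because they carry the same 2-chlorophenyl group. Nothing recorded for the series bears on this step, so no cause can be offered for it.

Because the exchange alters the chlorine, the methyl and the link to the ring all at once, this one step cannot assign any share of the outcome to a single one of these features, and plain benzyl or 4-chlorobenzyl on the same nitrogen would be needed to separate them. Also open, going by these compounds, is whether a quite different substituent at this place, such as a basic amine, a carboxylic acid or a longer alkyl chain, would produce a step beyond the scatter.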